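Boc-aminomethyl piperidine amide in the spiro series

The source may report more compounds than this note shows. Statements on the series, on what has been measured and on what is new or still open speak of the compounds shown alone.

Measured so far:
compound 1 `CC(C)(C)OC(=O)NCC1CCCN(C(=O)CN2CN(c3ccccc3)C3(CCN(C(=O)c4ccc(C5CCCCC5)cc4)CC3)C2=O)C1` — 3800 nM
compound 2 `CC(C)(C)c1ccc(C(=O)N2CCC3(CC2)C(=O)N(CC(=O)N2CCNCC2)CN3c2ccccc2)cc1` — 22000 nM
compound 3 `CC(C)(C)c1ccc(C(=O)N2CCC3(CC2)C(=O)N(CC(=O)N2CCCC(O)C2)CN3c2ccccc2)cc1` — 12200 nM

All numbers come from an assay on HEK293 cells for displacement of a labelled ligand from NPC1-like intracellular cholesterol transporter 1 (Homo sapiens); a higher number here means a weaker inhibitor, a lower number a stronger inhibitor. Compound 3 gives 12200 nM, the second highest of the three; compound 2 sits nearest to it, while compound 1 lies furthest away, beyond the scatter. Among the measured compounds shown here, the only single-place step on record, a 1.8-fold lower number from compound 2 to compound 3 (0.26 log units; within the scatter), changes the terminal amide ring and stays within the scatter.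

Compound 4 `CC(C)(C)OC(=O)NCC1CCCN(C(=O)CN2CN(c3ccccc3)C3(CCN(C(=O)c4ccc(C(C)(C)C)cc4)CC3)C2=O)C1` keeps the core of compound 3 and differs from it in one place: ((tert-butoxycarbonyl)amino)methyl in place of hydroxy on a saturated ring carbon. The same ((tert-butoxycarbonyl)amino)methyl piperidine is already present in compound 1, whose core otherwise differs from compound 4 only in the aryl substituent of the benzamide; compound 1 gives 3800 nM, a lower number than compound 3 shows. The step from compound 2 to compound 3 suggests that small changes on this amide ring move the number little, whereas the gap between compound 1 and compound 3 points to a lower number for the larger group. Compound 4 is therefore expected to fall between these two, with an estimated step of a 2.2-fold lower number from compound 3 to compound 4 (0.35 log units; beyond the scatter). The estimate for compound 4 in this assay is 5500 nM, with a range of 2200 nM to 14000 nM.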

Compound 4, half-maximal inhibitory concentration: 9500 nM
The estimate for compound 4 lay 1.7-fold (0.24 log units) below the measured number; low and high end bracket the measured number.
By their numbers in this assay, from the lowest: compound 1; then compounds 4, 3 and 2 (each within the scatter of the next, the first and the last beyond it).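

In this assay, ((tert-butoxycarbonyl)amino)methyl in place of hydroxy on this saturated ring carbon, two ring bonds from the ring nitrogen, gives a 1.3-fold lower number from compound 3 to compound 4 (0.11 log units; within the scatter); a group of 9 heavy atoms replacing one of 1 heavy atom therefore leaves the number within the scatter. With that same piperidine held fixed, tert-butyl in place of cyclohexyl on the aromatic carbon gives a 2.5-fold higher number from compound 1 to compound 4 (0.40 log units; beyond the scatter), so the lower number of compound 1 goes with its cyclohexyl group, not with the ((tert-butoxycarbonyl)amino)methyl group, and this modest step is the only one of the two beyond the scatter. Nothing available bears on why either step has the size it has.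

It remains open whether a free aminomethyl group or a carboxylic acid on the same ring carbon would also stay within the scatter of compound 3, since the only groups shown there are hydroxy and ((tert-butoxycarbonyl)amino)methyl. Going by these compounds, it is also open whether cyclohexyl in place of tert-butyl would give a similar step when the amide ring carries hydroxy.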